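From compound 3 to compound 4: methyl for fluoro

The compounds below may be only part of what the source reports. "The series", "measured", "known", "first", "only" and "open" are said of these compounds alone.

In a toxicity assay on MT4 cells (Homo sapiens) for cytotoxicity, read by MTT assay (a higher number here means that more compound is tolerated, a lower number that less compound is tolerated), compound 1 (`COc1cc(-c2ccc(C#N)cc2)ccc1Oc1cc(N)nc(Nc2ccc(C#N)cc2)n1`) gives 120000 nM and compound 2 (`COc1cc(Oc2cc(N)nc(Nc3ccc(C#N)cc3)n2)ccc1-c1ccc(C#N)cc1`) gives 12900 nM on the same scale. Compound 3 (`Cc1cc(-c2cccc(F)c2)cc(C)c1Oc1cc(N)nc(Nc2ccc(C#N)cc2)n1`) gives 24700 nM here, which lies within the scatter of compound 2 and beyond the scatter below compound 1. Compound 4 (`Cc1cccc(-c2cc(C)c(Oc3cc(N)nc(Nc4ccc(C#N)cc4)n3)c(C)c2)c1`) differs from compound 3 in one place (methyl in place of fluoro on an aromatic carbon), with methyl in place of fluoro on an aromatic carbon. Among the compounds with values here, no measured pair isolates a single change, so the data give no direct guide to this step. The estimate is a small step (a 1.1-fold lower number from compound 3 to compound 4 (0.05 log units; within the scatter)), not expected to exceed the scatter in this assay in either direction. For compound 4 the estimated value is 22000 nM with an expected range from 8000 nM to 60000 nM in this measurement.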

Compound 4, half-maximal cytotoxic concentration: 27600 nM
Beside the measured number, compound 4's estimate is 1.3-fold (0.10 log units) below it, within the range that was stated.
By their numbers in this assay, from the lowest: compounds 2, 3 and 4 (each within the scatter of the next, the first and the last beyond it); then compound 1.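

In this assay the series now has its first single-place comparison, and it reads a 1.1-fold higher number from compound 3 to compound 4 (0.05 log units; within the scatter) on the change from 3-fluorophenyl to 3-methylphenyl. At this aromatic carbon, meta to a large group, fluoro and methyl cannot be told apart in this read-out, so swapping one heavy atom for another without adding a ring, donor, acceptor or charge leaves the cytotoxicity reading unresolved. Nothing available bears on the reason for this result.

Still open, as far as these compounds go, is whether an amine, a carboxylic acid or a longer chain at this position would also stay within the scatter. From the compounds shown here alone, the same swap on other positions of this ring also remains open.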